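The compounds below may be only part of what the source reports. "The series", "measured", "known", "first", "only" and "open" are said of these compounds alone.

Compound 1 `Oc1ccc(-c2cc(-c3ccc(C(F)(F)F)cc3)cc(-c3ccccc3O)n2)cc1` reaches only a limit of the assay in a functional assay on HeLa cells (Homo sapiens) for inhibition (a lower number here means a stronger inhibitor, a higher number a weaker inhibitor), reported as > 50000 nM. Within the data shown here, compound 2 `Oc1ccc(-c2cc(-c3cccc(C(F)(F)F)c3)cc(-c3cccc(O)c3)n2)cc1` gives 16200 nM in this assay and is the only compound with a number. The remaining value, that of compound 1, is the limit (the limit of > 50000 nM in this assay, at which 1 of the 2 values shown sits). Compound 3 `Oc1ccc(-c2cc(-c3ccc(C(F)(F)F)cc3)cc(-c3cccc(O)c3)n2)cc1` differs from compound 2 by 4-(trifluoromethyl)phenyl in place of 3-(trifluoromethyl)phenyl on an aromatic carbon. Among the measured compounds shown here, no step between measured compounds is available. Compound 1 also carries a 4-(trifluoromethyl)phenyl group and sits at the limit of > 50000 nM in this assay, at which 1 of the 2 values shown sits, so a move toward weaker inhibition beyond the scatter is expected. The expected step is a 2.2-fold higher number from compound 2 to compound 3 (0.33 log units; beyond the scatter). Compound 3 is estimated at 35000 nM, within 10000 nM to 120000 nM.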

Compound 3, half-maximal inhibitory concentration: 17300 nM
Beside the measured number, compound 3's estimate is 2.0-fold (0.31 log units) above it; low and high end bracket the measured number.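

In this assay, the 3-(trifluoromethyl)phenyl and 4-(trifluoromethyl)phenyl groups read alike at this position, with a 1.1-fold higher number from compound 2 to compound 3 (0.03 log units; within the scatter). The step beyond the scatter lies elsewhere on the core, at 3-hydroxyphenyl in place of 2-hydroxyphenyl, with an at least 2.8-fold lower number from compound 1 to compound 3 (0.46 log units; beyond the scatter). The value of compound 1 is a limit and not a number: the limit of > 50000 nM in this assay, at which 1 of the 3 values shown sits.

Going by these compounds, what an amine or a carboxylic acid in place of the trifluoromethyl group would do at this position stays open. Also open, on these data alone, is whether the two trifluoromethyl placements still read alike alongside 2-hydroxyphenyl.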